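A few compounds are considered here, and "the series" means these few. Any claim that something is new, unique, unknown or untested is made for them only; others in the source may bear on it.

Measured so far in an assay on CHO cells for displacement of a labelled ligand from adenosine receptor A1 (Homo sapiens), tested at 10 uM; on this read-out lower numbers stand for less inhibition and higher numbers for more inhibition at the one concentration tested (going by the name of the read-out):

compound 1 `O=C(Nc1nn(-c2ccccc2)c(=O)c2ccccc12)c1ccccc1` — 44%
compound 2 `COc1ccc(NC(=O)Nc2nn(-c3ccccc3)c(=O)c3ccccc23)cc1` — 4%
compound 3 `Nc1nn(-c2ccccc2)c(=O)c2ccccc12` — 24%

Compound 2 stands lowest of the three numbers; compound 3 is nearest, and compound 1 furthest, with both steps beyond the scatter. Two steps are known. Compound 1 to compound 2, (4-methoxyphenyl)amino in place of phenyl on a carbonyl carbon, gives a number 40 percentage points lower from compound 1 to compound 2 (beyond the scatter). Compound 1 to compound 3, hydrogen in place of benzoyl on a nitrogen on an aromatic ring, gives a number 20 percentage points lower from compound 1 to compound 3 (beyond the scatter).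

Compound 4 `O=C(Nc1ccccc1)Nc1nn(-c2ccccc2)c(=O)c2ccccc12` is not yet measured. It differs from compound 2 as follows: hydrogen in place of methoxy on an aromatic carbon. Going by the values given here, no measured step matches the removal of a methoxy; the only step touching this part of the structure is the one from compound 1 to compound 2, which shows the urea with a 4-methoxyphenyl group far below the benzamide. That step bears on compound 4 only indirectly. The expected step in this assay from compound 2 is small, at most near the edge of the scatter and likely upward: a number 6 percentage points higher from compound 2 to compound 4 (within the scatter). Compound 4 is therefore estimated at 10%, with a range from 0% to 25%.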

Compound 4, a percentage reported as inhibition, at one concentration (the size of the read-out at that concentration, not a potency): 44%
The estimate for compound 4 lay 34 percentage points below the measured number; measured number above the stated range.
By their numbers in this assay, from the lowest: compound 2; then compound 3; then compounds 1 and 4 (each within the scatter of the next).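

In this assay, a number 40 percentage points higher from compound 2 to compound 4 (beyond the scatter) shows that the low number of compound 2 goes with the methoxy, para to a large group, and not with the urea as such. With the methoxy gone, no change at the digits printed from compound 1 to compound 4 (within the scatter), so anilino and phenyl on the carbonyl carbon cannot be told apart here, while a number 20 percentage points higher from compound 3 to compound 4 (beyond the scatter) shows that the phenylcarbamoyl group on the nitrogen gives a higher number than the free amine. No measurement shown here accounts for the size of the methoxy step.

As far as these compounds go, it remains open whether a methyl, a chlorine or a hydroxyl at the same place on the anilino ring would lower the number as methoxy does. Also open, from the compounds shown here alone, is whether a 4-methoxyphenyl group on the carbonyl carbon of the benzamide of compound 1 would give a similar fall.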